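Swapping a Pyridinylmethylamino Arm for an Azepane Ring

The source may hold more compounds than are shown below. What is called first, only, known or untested is meant among the compounds shown, and "the series" means these compounds.

Measured compounds:
- compound 1, `CC(C(=O)NCc1ccc(C(F)(F)F)nc1NCc1cccnc1)c1ccc(NS(C)(=O)=O)c(F)c1`, "not active" (no number reported)
- compound 2, `C[C@@H](C(=O)NCc1ccc(C(F)(F)F)nc1N1CCC(c2ccccc2)CC1)c1ccc(NS(C)(=O)=O)c(F)c1`, 7.5 nM
- compound 3, `CC(C(=O)NCc1ccc(C(F)(F)F)nc1N1CCC(C(=O)c2ccc(F)cc2)CC1)c1ccc(NS(C)(=O)=O)c(F)c1`, 3.9 nM

In a functional assay on CHO-K1 cells for antagonist activity at transient receptor potential cation channel subfamily V member 1 (Homo sapiens), read by FLIPR (on this read-out higher numbers stand for weaker inhibition and lower numbers for stronger inhibition), compound 1 is recorded as "not active" (no number reported), so no number stands for it and it cannot be placed on the scale at all. Compound 2 gives 7.5 nM and compound 3 gives 3.9 nM in this assay; these two values lie within the usual scatter of each other, so neither can be called the stronger.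

Compound 4, `CC(C(=O)NCc1ccc(C(F)(F)F)nc1N1CCCCCC1)c1ccc(NS(C)(=O)=O)c(F)c1`, has not been measured yet. It differs from compound 1 in one place: azepan-1-yl in place of ((pyridin-3-yl)methyl)amino on an aromatic carbon. Within the data shown here, no measured step covers this change, so its size in this assay cannot be read from a neighbouring pair. The expectation rests only on compound 2 and compound 3, which both carry a saturated nitrogen ring at the same place; compound 2 gives 7.5 nM and compound 3 gives 3.9 nM. Compound 4 is therefore expected to be clearly active, though plausibly weaker than those two, with an estimated value of 100 nM and a range from 15 nM to 800 nM.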

Compound 4, inhibition constant: 0.8 nM
The estimate for compound 4 lay 130-fold (2.10 log units) above the measured number; the measured number lies below the stated range.
By their numbers in this assay, from the lowest: compound 4; then compounds 3 and 2 (each within the scatter of the next).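

In this assay, among these compounds, compound 1 stands as ("not active" (no number reported)) and compound 4 gives (0.8 nM), so no step between them can be read. No measurement shown bears on this result.
The compounds shown leave open which part of the exchanged group matters for activity.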